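Hydrazone Heteroaryl Swap on an Adenosine Receptor Ligand Series

The source may hold more compounds than are shown below. What is called first, only, known or untested is meant among the compounds shown, and "the series" means these compounds.

Compound 1 `Nc1nc(N/N=C/c2ccc(-c3ccc(Br)cc3)o2)nc2c1ncn2[C@@H]1O[C@H](CO)[C@@H](O)[C@H]1O`: 4.5 nM
Compound 2 `COc1cc(/C=N/Nc2nc(N)c3ncn([C@@H]4O[C@H](CO)[C@@H](O)[C@H]4O)c3n2)ccc1OCc1ccccc1`: 9140 nM
Compound 3 `CCCCc1nc(/C=N/Nc2nc(N)c3ncn([C@@H]4O[C@H](CO)[C@@H](O)[C@H]4O)c3n2)c(Cl)[nH]1`: 12 nM

The three measured compounds share one core and differ only in the aryl group hung from the hydrazone. In an assay on CHO-K1 cells for displacement of a labelled ligand from adenosine receptor A1 (Homo sapiens), read by scintillation counting, with a stated time of 60 min (on this read-out higher numbers stand for weaker inhibition and lower numbers for stronger inhibition), compound 3 gives 12 nM, the second highest of the three numbers. Its nearest neighbour is compound 1, whose number is lower by a margin beyond the scatter; the furthest is compound 2, whose number is higher by a very wide margin. Because no two of these compounds differ in just one place, none of the gaps can be pinned on a single change.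

Compound 4 `Nc1nc(N/N=C/c2cncs2)nc2c1ncn2[C@@H]1O[C@H](CO)[C@@H](O)[C@H]1O` is the next step from compound 3. The change is 1,3-thiazol-5-yl in place of 2-butyl-5-chloro-1H-imidazol-4-yl on a carbon with a double bond to nitrogen. The group that leaves is larger and carries a hydrogen-bond donor; the group that enters is smaller and carries none. A move of this kind from compound 3 to compound 4 is expected to cost some affinity, with the step of a 3.3-fold higher number from compound 3 to compound 4 (0.52 log units; beyond the scatter) estimated as modest but beyond the scatter. Compound 4 is therefore expected to show about 40 nM in this assay, within a range of 8 nM to 300 nM.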

Compound 4, inhibition constant: 22 nM
Estimate against measurement, compound 4: 1.8-fold (0.26 log units) above; measured number inside the range.
By their numbers in this assay, from the lowest: compound 1; then compounds 3 and 4 (each within the scatter of the next); then compound 2.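

In this assay, going by these compounds alone, the swap of 2-butyl-5-chloro-1H-imidazol-4-yl for 1,3-thiazol-5-yl on this carbon gives a 1.8-fold higher number from compound 3 to compound 4 (0.26 log units; within the scatter), the first change in this set that can be read at a single place. For this pair, the group with fewer heavy atoms and no hydrogen-bond donor gives a number within the scatter of the larger group, so the butyl chain, the chlorine and the ring hydrogen-bond donor of the group that leaves are not required for binding in this range. No measurement given here explains why the two groups read alike.

The compounds shown leave open whether adding a butyl chain or a chlorine to the 1,3-thiazol-5-yl ring would shift the number. Also open, from the compounds shown here alone, is what a plain phenyl ring would give at this place.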